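Working notes: from compound 2 to compound 3

The compounds below may be only part of what the source reports. "The series", "measured", "known", "first", "only" and "open" are said of these compounds alone.

- compound 1 `FC(F)(F)c1ccc(-c2nn(-c3ccccc3)cc2CNc2ccc(Cl)cc2)cc1` gives 10000 nM in an ADME assay on Vero 76 cells (Chlorocebus sabaeus) for cytotoxicity, read by MTT assay, with a stated time of 96 h; on this read-out lower numbers stand for higher toxicity in this test and higher numbers for lower toxicity in this test
- compound 2 `Cc1ccc(NCc2cn(-c3ccccc3)nc2-c2ccc(C(F)(F)F)cc2)cc1` gives 82000 nM in this assay

For the measured compounds named here, of the two measured compounds, compound 2 holds the highest number at 82000 nM in this assay so far. Compound 3 `Cc1ccc(NCc2cn(-c3ccccc3)nc2-c2ccc(Br)cc2)cc1` keeps the rest of compound 2 and has bromo in place of trifluoromethyl on an aromatic carbon, para to a large group (bromo in place of trifluoromethyl on an aromatic carbon). Going by the values given here, the only measured step is an 8.2-fold higher number from compound 1 to compound 2 (0.91 log units; beyond the scatter) and it exchanges chloro for methyl, which is a different change. Among the compounds with values here, no measured compound carries bromo, so that step bears only indirectly. With compound 2 at 82000 nM and the chloro compound 1 at 10000 nM in view, a modest move to a lower number is expected. The expected step is a 2.3-fold lower number from compound 2 to compound 3 (0.37 log units; beyond the scatter) and it is uncertain. Compound 3 is estimated at 35000 nM (10000 nM to 100000 nM) as the expected value and range.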

Compound 3, half-maximal cytotoxic concentration: > 100000 nM
Compound 3: no number, only a limit; the forecaster's own chance of this, stated with the estimate: 20%; at least 2.8-fold (0.45 log units) between middle value and limit.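

In this assay compound 3 gives > 100000 nM, which is a limit of the assay and not a number: the limit of > 100000 nM in this assay, at which 1 of the 3 values shown sits.

The change from 4-(trifluoromethyl)phenyl to 4-bromophenyl gives an at least 1.2-fold higher number from compound 2 to compound 3 (0.08 log units; that floor lies within the scatter), so the floor alone does not separate the two compounds. For the compounds shown here, this is the first look at this position, since the earlier step changed a different place, and it shows that bromo here brings no sign of higher toxicity in this test.

Going by these compounds, how far compound 3 lies past the limit remains open, as does whether an 8.2-fold higher number from compound 1 to compound 2 (0.91 log units; beyond the scatter) would carry over with bromo in this position. Also open, on these data alone, is how this assay would read with an amine or a carboxylic acid at this position.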